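Swapping methoxy for chloro on the pendant phenyl ring

A few compounds are considered here, and "the series" means these few. Any claim that something is new, unique, unknown or untested is made for them only; others in the source may bear on it.

Measured so far:
compound 1, `COc1ccc(C2=NN(C3=NC(=O)/C(=C4\C(=O)Nc5ccccc54)S3)C(c3ccc(OC)cc3)C2)cc1`, 100000 nM
compound 2, `COc1ccc(C2=NN(C3=NC(=O)/C(=C4\C(=O)Nc5ccc(Br)cc54)S3)C(c3ccc(OC)cc3)C2)cc1`, 62700 nM
compound 3, `COc1ccc(C2=NN(C3=NC(=O)/C(=C4\C(=O)Nc5ccc(Cl)cc54)S3)C(c3ccc(OC)cc3)C2)cc1`, 75200 nM

In a functional assay on cells (Leukemia cell, Homo sapiens) for cytotoxicity, read by sulforhodamine B assay, with a stated time of 48 h (on this read-out lower numbers stand for stronger inhibition of growth and higher numbers for weaker inhibition of growth), compound 3 gives 75200 nM, the second highest of the three numbers; its neighbours lie within the scatter, a 1.2-fold higher number from compound 2 to compound 3 (0.08 log units; within the scatter) and a 1.3-fold lower number from compound 1 to compound 3 (0.12 log units; within the scatter). Compound 4, `COc1ccc(C2=NN(C3=NC(=O)/C(=C4\C(=O)Nc5ccc(Cl)cc54)S3)C(c3ccc(Cl)cc3)C2)cc1`, differs from compound 3 by chloro in place of methoxy on an aromatic carbon, para to a large group, so that 4-methoxyphenyl becomes 4-chlorophenyl. Within the data shown here, no measured step bears directly on this exchange; the only steps known, a 1.6-fold lower number from compound 1 to compound 2 (0.20 log units; within the scatter) and a 1.3-fold lower number from compound 1 to compound 3 (0.12 log units; within the scatter), concern halogen for hydrogen on the other ring and stayed within the scatter. Compound 4 is therefore expected to show no step beyond the scatter, a 1.1-fold lower number from compound 3 to compound 4 (0.03 log units; within the scatter). The value of compound 4 in this assay is estimated at 70000 nM, within 35000 nM to 140000 nM.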

Compound 4, concentration for total growth inhibition: 890 nM
Compound 4: middle estimate off by 79-fold (1.90 log units), on the high side; the measured number lies below the stated range.
By their numbers in this assay, from the lowest: compound 4; then compounds 2, 3 and 1 (each within the scatter of the next).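

In this assay the exchange of 4-methoxyphenyl for 4-chlorophenyl gives an 84-fold lower number from compound 3 to compound 4 (1.93 log units; beyond the scatter) and is the only step among these compounds that lies beyond the scatter. The pendant ring, at the place para to a large group, therefore matters far more here than the halogen-for-hydrogen changes on the other ring, whose steps stayed within the scatter. Nothing available here accounts for the size of this step.

The compounds shown leave open whether chloro is specifically required at this place or whether a group such as an amine or trifluoromethyl would serve as well. They also leave open whether the same exchange would give a step of this size in compound 1 or compound 2, which carry hydrogen and bromo on the other ring.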